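The source may report more compounds than this note shows. Statements on the series, on what has been measured and on what is new or still open speak of the compounds shown alone.

Measured compounds:
compound 1 `CC(CC(=O)O)CC(=O)c1c(CCCCCCc2ccccc2)n(C)c2ccc(Cl)cc12` — 0.28 nM
compound 2 `C[C@H](CC(=O)O)CC(=O)c1c([C@H](O)CCCCCc2ccccc2)n(C)c2ccc(Cl)cc12` — 260 nM
compound 3 `C[C@@H](CC(=O)O)CC(=O)c1c([C@@H](O)CCCCCc2ccccc2)n(C)c2ccc(Cl)cc12` — 120 nM

In a functional assay for antagonist activity at Oxoeicosanoid receptor 1 (Homo sapiens), read by fluorescence and calcium flux, with stated times of 2 min and 1 min (a higher number here means a weaker inhibitor, a lower number a stronger inhibitor), compound 1 holds the lowest number of the three: compound 3 sits a 2.2-fold lower number from compound 2 to compound 3 (0.34 log units; beyond the scatter) below compound 2, and both stand far above compound 1. Among the measured compounds shown here, the only measured step is that from compound 2 to compound 3, a change of configuration alone, (the fact that compounds 2 and 3 differ only in the configuration as drawn); it says nothing about the length of the chain that carries the phenyl, which is the matter at hand here.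

Compound 4 `CC(CC(=O)O)CC(=O)c1c(CCCc2ccccc2)n(C)c2ccc(Cl)cc12` is compound 1 with phenyl in place of 3-phenylpropyl on a saturated chain carbon, three bonds along the chain from an aromatic carbon. For the measured compounds named here, no measured pair shows a shortening of this chain, so the expectation rests only on compound 1 as the anchor, with its value of 0.28 nM, and on the general observation that the low number of compound 1 leaves more room to rise than to fall. A step of a 36-fold higher number from compound 1 to compound 4 (1.55 log units; beyond the scatter) toward a higher number is expected, as the removal of three chain carbons is a substantial change to the group that distinguishes the strongest compound from the rest. Compound 4 is therefore estimated at 10 nM, with a range from 1 nM to 200 nM.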

Compound 4, half-maximal inhibitory concentration: 223 nM
For compound 4 the middle estimate is 22-fold (1.35 log units) below the measured one, outside the stated range (above it).
By their numbers in this assay, from the lowest: compound 1; then compounds 3, 4 and 2 (each within the scatter of the next, the first and the last beyond it).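

In this assay, among the compounds shown here, the step of an 800-fold higher number from compound 1 to compound 4 (2.90 log units; beyond the scatter) is the first measured change at this position, and it is large: phenyl in place of 3-phenylpropyl, on a saturated chain carbon, three bonds along the chain from an aromatic carbon, costs nearly all of the low number that marks the top of the series. Everything else in the two structures is shared, and the groups that leave and enter each carry one six-membered aromatic ring of carbon only, with no hydrogen-bond donors or acceptors and no net charge, so the step tracks the carbon count of the chain that carries the ring rather than the loss of the ring itself. The only supporting observation on these compounds concerns another pair and does not bear on this step, so no cause can be given for it.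

For the compounds shown here, with only two chain lengths in hand, it remains open whether the number rises gradually or sharply as the chain shortens, and intermediate groups such as a 4-phenylbutyl chain would settle that. From the compounds shown here alone, it is also open whether a longer chain, or a carboxylic acid or an amine at the chain end in place of the phenyl, would keep a number as low as that of compound 1.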